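Triazole to isoxazole on the amide of compound 1

The source may hold more compounds than are shown below. What is called first, only, known or untested is meant among the compounds shown, and "the series" means these compounds.

Measured compounds in a physicochemical assay for solubility, read by nephelometry, measured as kinetic solubility, at pH 2.0; a higher number here means a more soluble compound, a lower number a less soluble compound:
Compound 1, `NCc1csc(NC(=O)c2cnn[nH]2)n1`, gives > 100 ug/mL, which is a limit of this assay and not a number.
Compound 2, `NCc1csc(NC(=O)c2cnnn2Cc2ccccc2)n1`, gives > 100 ug/mL, again a limit and not a number.
Compound 3, `CC(C)(C)c1cc(C(=O)Nc2ccccc2)n(Cc2ccccc2)n1`, gives 1.6 ug/mL.

Compound 1 stands at the limit of this assay, so no number is known for it, and the step from compound 1 to compound 2 is a step that the two limits leave unreadable from compound 1 to compound 2. Among the measured compounds shown here, compound 3 sits far lower, but no single step connects it to compound 1, so its value only shows that a member of this set can fall well below the limit.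

Compound 4, `NCc1csc(NC(=O)c2ccon2)n1`, differs from compound 1 as follows: 1,2-oxazol-3-yl in place of 1H-1,2,3-triazol-5-yl on a carbonyl carbon. For the measured compounds named here, no measured step involves this change; the only measured step, benzyl in place of hydrogen on an aromatic nitrogen, is unreadable in this assay because of the limit of > 100 ug/mL in this assay, at which 2 of the 3 values shown sit. With no readable step to lean on, and the shared core with its aminomethyl group kept, the expectation is that compound 4 remains at or near the limit, with an expected step of a number no higher from compound 1 to compound 4 (the limit leaves the size open). Compound 4 is therefore estimated at 100 ug/mL, in a range from 40 ug/mL to 200 ug/mL, and the assay is expected most likely to report a limit again.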

Compound 4, solubility: 50 ug/mL
Estimate against measurement, compound 4: 2.0-fold (0.30 log units) above, within the range that was stated.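

In this assay, among the compounds shown here, compound 4 gives 50 ug/mL, the only number so far among the compounds carrying the shared core with its aminomethyl group. Compound 1 remains a limit, > 100 ug/mL, and not a number. 1,2-oxazol-3-yl in place of 1H-1,2,3-triazol-5-yl on a carbonyl carbon is an at least 2.0-fold lower number from compound 1 to compound 4 (0.30 log units; that floor lies within the scatter), so this change has a floor but no known size, and that floor does not separate the pair from the scatter.

On these data alone, the step that adds benzyl cannot be read, because the values on both sides of it are the same limit: the limit of > 100 ug/mL in this assay, at which 2 of the 4 values shown sit. Still open is how a carboxylic acid on the 1,2-oxazol-3-yl group, or a longer chain in place of the aminomethyl group, would read in this assay.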